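A few compounds are considered here, and "the series" means these few. Any claim that something is new, unique, unknown or untested is made for them only; others in the source may bear on it.

Measured compounds:
- compound 1, `COc1cc(NS(=O)(=O)c2ccc(N3CCNC3=O)cc2)cc(OC)c1OC`: 19 nM
- compound 2, `CCc1cccc(NS(=O)(=O)c2ccc(N3CCNC3=O)cc2)c1`: 230 nM

Both compounds were tested in a functional assay on K562 cells (Homo sapiens) for antiproliferative activity, read by sulforhodamine B assay, with a stated time of 48 h; a higher number here means a weaker inhibitor, a lower number a stronger inhibitor. Compound 1 gives 19 nM, the lowest number of the two, and compound 2 gives 230 nM, a gap that lies beyond the usual scatter, so compound 1 is the stronger inhibitor of the pair. For the measured compounds named here, no pair of measured compounds differs in only one place, so no single step has been measured directly.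

The next compound, compound 3, `COc1cc(NS(=O)(=O)c2ccc(N3CCNC3=O)cc2)cc(OC)c1`, is derived from compound 1 by one change: hydrogen in place of methoxy on an aromatic carbon. The group that leaves sits ortho to two methoxy groups and para to a large group. Whether removing one of three methoxy groups matters cannot be read from the measured pair, so the step is expected to be a moderate weakening, beyond the scatter, with a 6.3-fold higher number from compound 1 to compound 3 (0.80 log units; beyond the scatter). Compound 3 is therefore expected to give about 120 nM, within a range from 30 nM to 500 nM.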

Compound 3, half-maximal inhibitory concentration: 110 nM
Compound 3: middle estimate off by 1.1-fold (0.04 log units), on the high side, and the stated range covers the measured number.
By their numbers in this assay, from the lowest: compound 1; then compound 3; then compound 2.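

In this assay, for the compounds shown here, the single change from methoxy to hydrogen on the aromatic carbon ortho to two methoxy groups and para to a large group gives a 5.8-fold higher number from compound 1 to compound 3 (0.76 log units; beyond the scatter) and so provides the first directly measured step. Compound 3 keeps the other two methoxy groups, yet the step lies beyond the usual scatter, so they do not by themselves preserve the number seen for compound 1. The methoxy group on this carbon therefore contributes to the lower number of compound 1, although nothing available here explains how.

Going by these compounds, whether an ethoxy group, a hydroxyl group or an amine on this carbon would give a lower or higher number than methoxy remains open. On these data alone, the separate contribution of each remaining methoxy group also stays unknown, since compound 3 retains both.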